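The source may hold more compounds than are shown below. What is called first, only, known or untested is meant among the compounds shown, and "the series" means these compounds.

Series notes. For the measured compounds named here, compound 3 `Cc1ccc(CN2C(=O)CC[C@H]2C(=N)NCc2ccccc2)cc1` sits at the bottom of the three numbers so far: in a functional assay on SH-SY5Y cells (Homo sapiens) for cytotoxicity, read by MTT assay, with stated times of 8 h, 30 min and 12 h, tested at 0.5 uM (a lower number here means a weaker effect, a higher number a stronger effect of the compound at the concentration tested), compound 3 gives 23.5%, with compound 1 `COc1ccc(CNC(=N)[C@@H]2CCC(=O)N2Cc2ccccc2)cc1` at 23.6% and compound 2 `COc1ccc(CNC(=N)[C@@H]2CCC(=O)N2Cc2ccc([N+](=O)[O-])cc2)cc1` at 25.4%, both gaps within the scatter. Going by the values given here, the single one-place step measured, a number 1.8 percentage points higher from compound 1 to compound 2 (within the scatter), concerns a different group and also stays within the scatter. Compound 4 `COc1ccc(CNC(=N)[C@@H]2CCC(=O)N2Cc2ccc(C)cc2)cc1` differs from compound 3 by methoxy in place of hydrogen on an aromatic carbon. Among the compounds with values here, no measured step carries this exact change, and the one aromatic substitution step seen gave no shift beyond the scatter, so no step beyond the scatter is expected in this assay for compound 4; the change is estimated at a number 0.5 percentage points higher from compound 3 to compound 4 (within the scatter). Compound 4 is therefore expected at 24%, between 16% and 33%.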

Compound 4, a percentage reported as activity, at one concentration (the size of the read-out at that concentration, not a potency): 21.9%
For compound 4 the middle estimate is 2.1 percentage points above the measured one; the measured number falls inside the stated range.
By their numbers in this assay, from the lowest: compounds 4, 3, 1 and 2 (each within the scatter of the next).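

Putting a methoxy group para to a large group, where the other compound carries hydrogen, gives a number 1.6 percentage points lower from compound 3 to compound 4 (within the scatter) in this assay, so this position takes the change without a shift beyond the scatter. Methyl in place of nitro gives a number 3.5 percentage points lower from compound 2 to compound 4 (within the scatter) and methyl in place of hydrogen gives a number 1.7 percentage points lower from compound 1 to compound 4 (within the scatter) so hydrogen, methyl and nitro at that place all stay within the scatter of one another. No available data explain these small steps.

As far as these compounds go, whether an amine or a carboxylic acid on that aromatic carbon, or a longer chain in place of methoxy, would move the number beyond the scatter remains open.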